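The source may hold more compounds than are shown below. What is called first, only, known or untested is meant among the compounds shown, and "the series" means these compounds.

Compound 3, `N#Cc1ccc(N2CCN(C(=S)SCc3ccc(C(=O)Nc4ccccc4N)cc3)CC2)cc1`, gives 41.4% in a functional assay on A-375 cells (Homo sapiens) for antiproliferative activity, read by CCK-8 assay, with a stated time of 72 h, tested at 2 uM (on this read-out lower numbers stand for a weaker effect and higher numbers for a stronger effect at the one concentration tested), and stands highest of the three measured numbers. Its nearest neighbour is compound 1, `Nc1ccccc1NC(=O)c1ccc(CSC(=S)N2CCN(c3ccc(Cl)cc3)CC2)cc1`, which gives 32.2%; the step of a number 9.2 percentage points higher from compound 1 to compound 3 (within the scatter) lies within the scatter. Compound 2, `COc1ccc(N2CCN(C(=S)SCc3ccc(C(=O)Nc4ccccc4N)cc3)CC2)cc1`, gives 28.1%, and the step of a number 13.3 percentage points higher from compound 2 to compound 3 (beyond the scatter) is the only one beyond the scatter, while a number 4.1 percentage points lower from compound 1 to compound 2 (within the scatter) is within it.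

Compound 4, `Nc1ccccc1NC(=O)c1ccc(CSC(=S)N2CCN(Cc3ccncc3)CC2)cc1`, differs from compound 3 by (pyridin-4-yl)methyl in place of 4-cyanophenyl on an amine nitrogen in a ring. None of the three measured steps makes a change of this kind: each of them exchanges one substituent on the aromatic ring that sits on the amine nitrogen, whereas here the whole 4-cyanophenyl is replaced. Those steps therefore bear on the question only by showing how little the numbers moved when that ring was varied. Going by the values given here, with no measured step of the same kind, compound 4 is estimated to give about 30%, with a range from 14% to 46%, which is expected to mean a step of a number 11.4 percentage points lower from compound 3 to compound 4 (beyond the scatter).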

Compound 4, a percentage reported as inhibition, at one concentration (the size of the read-out at that concentration, not a potency): 33.1%
Beside the measured number, compound 4's estimate is 3.1 percentage points below it; low and high end bracket the measured number.
By their numbers in this assay, from the lowest: compounds 2, 1, 4 and 3 (each within the scatter of the next, the first and the last beyond it).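

In this assay the steps of a number 8.3 percentage points lower from compound 3 to compound 4 (within the scatter) and a number 5 percentage points higher from compound 2 to compound 4 (within the scatter) and a number 0.9 percentage points higher from compound 1 to compound 4 (within the scatter) show that exchanging the whole aromatic group on the amine nitrogen gave no change beyond the scatter. Going by these compounds alone, the earlier compounds varied only a substituent on that ring, so compound 4 is the first indication that this position accepts (pyridin-4-yl)methyl in place of a substituted phenyl ring. No supporting data bear on this result.

The compounds shown leave open which part of the change matters, since a benzyl group or a pyridin-4-yl group attached directly to the nitrogen would be needed to separate the ring from the added carbon. They also leave open whether a saturated ring such as cyclohexyl, or a simple alkyl chain, would hold up at this position.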